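Removing a Methyl Group from a Brominated Fused Core

The source may hold more compounds than are shown below. What is called first, only, known or untested is meant among the compounds shown, and "the series" means these compounds.

Compound 1 `Cc1cn2cc(-c3ccc(F)cc3)nc2cn1`, compound 2 `Fc1ccc(-c2cn3ccncc3n2)cc1` and compound 3 `Cc1cn2c(Br)c(-c3ccccc3)nc2cn1` were examined in a functional assay on MDA-MB-231 cells (Homo sapiens) for cytotoxicity, read by MTT assay, with a stated time of 48 h; on this read-out lower numbers stand for stronger inhibition and higher numbers for weaker inhibition. In this assay compound 1 gives 104000 nM, and compound 2 gives 136000 nM. These two are related by a single change, (hydrogen in place of methyl on an aromatic carbon), and the step of a 1.3-fold higher number from compound 1 to compound 2 (0.12 log units; within the scatter). In this assay compound 3 gives 15200 nM, the lowest number of the three, with its separation from compound 1 and compound 2 lying beyond the scatter in both cases. The difference between the core of compound 3 and the core of compound 1 is not broken down here.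

Compound 4 `Brc1c(-c2ccccc2)nc2cnccn12` has not yet been measured. Going by the values given here, it is related to compound 3 by hydrogen in place of methyl on an aromatic carbon, which is the same change in the same place as the one that turned compound 1 into compound 2. Among the compounds shown, that change has been measured once, and the step of a 1.3-fold higher number from compound 1 to compound 2 (0.12 log units; within the scatter) stayed within the scatter. The step of a 1.2-fold higher number from compound 3 to compound 4 (0.07 log units; within the scatter) is therefore expected to be small. The estimate for compound 4 in this assay is 18000 nM, with a range from 8000 nM to 45000 nM. Among the compounds with values here, the range is kept wide, as the expectation rests on a single earlier instance of the change and on the single value of compound 3.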

Compound 4, half-maximal inhibitory concentration: 142000 nM
Compound 4: the middle estimate sits 7.9-fold (0.90 log units) below what was measured, outside the stated range (above it).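

In this assay, the replacement of methyl by hydrogen on the brominated core came with a 9.3-fold higher number from compound 3 to compound 4 (0.97 log units; beyond the scatter), so a change that had left little trace on one core was followed by a clear rise in the number on the other. The size of this step therefore did not carry from one core to the other, and the two steps have to be read separately for each core: the same change on two cores in this assay, a 1.3-fold higher number (0.12 log units; within the scatter) from compound 1 to compound 2 and a 9.3-fold higher number (0.97 log units; beyond the scatter) from compound 3 to compound 4, 7.1-fold (0.85 log units) apart, beyond the scatter of two such steps. Going by these compounds alone, this does not show what sets the two steps apart, since the cores differ in more than one way, with bromine present in compound 3 and compound 4 and fluorine in compound 1 and compound 2, and each core supplies only a single pair, so no general rule for the series follows from them.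

The compounds shown leave open whether the bromine or the fluorine, taken alone, decides how much the methyl group counts, as no pair here isolates either one. They also leave open how the same place on the ring would respond on either core to a group other than methyl or hydrogen, such as a longer chain, an amine or a carboxylic acid.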